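Swapping the aryl group on the isoxazoline carbon

This account rests on a few compounds, and the source may have more. Where it says the series, first, only, none or still open, it means among the compounds named here.

Among the measured compounds shown here, compound 1 `COc1cc(-n2nnnc2-c2ccc(OCC3CC(c4cccc(Cl)c4)=NO3)c(N)c2)cc(OC)c1OC` is tested in a functional assay on A549 cells (Homo sapiens) for cytotoxicity, read by MTT assay, with a stated time of 48 h (a lower number here means a stronger inhibitor, a higher number a weaker inhibitor), and gives 1340 nM, the lowest of the two numbers measured so far. Its closest neighbour, compound 2 `COc1ccc(F)c(C2=NOC(COc3ccc(-c4nnnn4-c4cc(OC)c(OC)c(OC)c4)cc3N)C2)c1`, gives 1510 nM; the step of a 1.1-fold higher number from compound 1 to compound 2 (0.05 log units; within the scatter) lies within the usual scatter, so the two cannot be told apart on these numbers.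

Compound 3 `COc1ccc(C2=NOC(COc3ccc(-c4nnnn4-c4cc(OC)c(OC)c(OC)c4)cc3N)C2)cc1O` has not yet been measured. It differs from compound 1 as follows: 3-hydroxy-4-methoxyphenyl in place of 3-chlorophenyl on a carbon with a double bond to nitrogen. For the measured compounds named here, the only measured step that bears on this change is the one from compound 1 to compound 2, where a different aryl group was placed on the same carbon with a double bond to nitrogen, and that step stayed within the scatter. On that basis no change beyond the scatter is expected for compound 3, and the step of a 1.1-fold higher number from compound 1 to compound 3 (0.05 log units; within the scatter) is estimated to be small. Compound 3 is therefore expected to give about 1500 nM, with a likely range from 700 nM to 3500 nM.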

Compound 3, half-maximal inhibitory concentration: 2130 nM
Compound 3: middle estimate off by 1.4-fold (0.15 log units), on the low side; the measured number falls inside the stated range.
By their numbers in this assay, from the lowest: compounds 1, 2 and 3 (each within the scatter of the next).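

In this assay, the step of a 1.6-fold higher number from compound 1 to compound 3 (0.20 log units; within the scatter) shows that this carbon with a double bond to nitrogen can carry 3-hydroxy-4-methoxyphenyl in place of 3-chlorophenyl with no change that can be told from the scatter, even though the entering group brings a hydrogen-bond donor and hydrogen-bond acceptors that the leaving group lacks. The step of a 1.4-fold higher number from compound 2 to compound 3 (0.15 log units; within the scatter) reads the same way, so the three aryl groups shown here cannot be separated on these numbers. Nothing at hand speaks to why this position responds so little to these swaps.

All three groups at this position are substituted phenyl rings. On these data alone, it remains open whether a group without an aromatic ring, such as cyclohexyl or a short alkyl chain, or a phenyl ring carrying an amine or a carboxylic acid, would also stay within the scatter.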